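The source may hold more compounds than are shown below. What is called first, only, known or untested is meant among the compounds shown, and "the series" means these compounds.

Measured so far in an ADME assay on microsomes from liver (Homo sapiens) for metabolic stability, tested at 2.5 uM; on this read-out higher numbers stand for fast clearance and lower numbers for slow clearance:
compound 1, `COc1cccc(-c2c(S(=O)(=O)c3ccc(OC)c(Cl)c3)cnc3cc(F)ccc23)c1`, gives 1.71 mL/min.
compound 2, `COc1ccc(S(=O)(=O)c2cnc3cc(F)ccc3c2-c2ccc(F)cc2)cc1Cl`, gives 1.29 mL/min.

Compound 1 holds the highest of the two numbers in this assay; its nearest neighbour is compound 2, with a 1.3-fold lower number from compound 1 to compound 2 (0.12 log units; within the scatter). Since that difference lies within the scatter, the two compounds are not ranked against each other here. The step from compound 1 to compound 2 exchanges the group on an aromatic carbon of the shared core, not the group on the sulfonyl sulfur.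

Compound 3, `COc1cccc(-c2c(S(=O)(=O)c3cc(Cl)cc(Cl)c3)cnc3cc(F)ccc23)c1`, has not been measured. Relative to compound 1 the change is 3,5-dichlorophenyl in place of 3-chloro-4-methoxyphenyl on a sulfonyl sulfur. Going by the values given here, no measured step alters the group on the sulfonyl sulfur, so the one step on hand, from compound 1 to compound 2, does not bear directly on this change. With nothing pointing in either direction, the step from compound 1 to compound 3 is expected to stay within the scatter, a 1.0-fold lower number from compound 1 to compound 3 (0.00 log units; within the scatter). Compound 3 is thus expected to give about 1.7 mL/min in this assay, with a range from 0.8 mL/min to 3.5 mL/min.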

Compound 3, intrinsic clearance in a liver preparation (reported as CLH), per the amount of preparation that the assay uses: 1.51 mL/min
Estimate against measurement, compound 3: 1.1-fold (0.05 log units) above; measured number inside the range.
By their numbers in this assay, from the lowest: compounds 2, 3 and 1 (each within the scatter of the next).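

In this assay, the change on the sulfonyl sulfur reads as a 1.1-fold lower number from compound 1 to compound 3 (0.05 log units; within the scatter). Going by these compounds alone, this gives the series its only measured step at this place: 3,5-dichlorophenyl in place of 3-chloro-4-methoxyphenyl, an exchange that removes the methoxy group and brings in a second chlorine, does not separate compound 3 from compound 1 on this read-out. No supporting measurement bears on why this exchange leaves the two compounds unseparated.

From the compounds shown here alone, both groups compared on the sulfonyl sulfur are chlorine-bearing phenyl rings, so it remains open whether a different kind of group at this place, such as a saturated piperidine ring, a basic amine or a carboxylic acid, would give a step beyond the scatter. Also open, going by these compounds, is how the shared core would read in this assay with 3,5-dichlorophenyl on the sulfonyl sulfur and 4-fluorophenyl on the aromatic carbon together, since each of these two changes has been read only on its own against compound 1.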